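From 1,2-Thiazol-5-yl to 1,3-Thiazol-2-yl: What Compound 4 May Give

The source may report more compounds than this note shows. Statements on the series, on what has been measured and on what is new or still open speak of the compounds shown alone.

Compound 3 `c1ccc(-c2ccns2)c(OCC2=NCCN2)c1` stands lowest of the three compounds measured in a functional assay with Alpha-1D adrenergic receptor (Homo sapiens) as the target, read by calcium flux; a lower number here means a smaller maximal response, a higher number a larger maximal response: compound 3 gives 82%. Its nearest neighbour is compound 1 `c1csc(-c2ccccc2OCC2=NCCN2)c1`, which in this assay gives 93%, and the furthest is compound 2 `c1ccc(-c2ccoc2)c(OCC2=NCCN2)c1`, which in this assay gives 126%. The step of a number 11 percentage points lower from compound 1 to compound 3 (beyond the scatter) was modest, whereas a number 44 percentage points lower from compound 2 to compound 3 (beyond the scatter) was large, and a number 33 percentage points higher from compound 1 to compound 2 (beyond the scatter) was large in the other direction.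

Compound 4 `c1ccc(-c2nccs2)c(OCC2=NCCN2)c1` differs from compound 3 by 1,3-thiazol-2-yl in place of 1,2-thiazol-5-yl on an aromatic carbon. Among the measured compounds shown here, no measured step exchanges one thiazolyl ring for another, so the bearing of the measured steps is indirect: they show that swapping one five-membered heteroaromatic ring for another on this aromatic carbon has moved the maximal response by amounts from modest to large, with compound 3 sitting at the low end. A modest step upward rather than a large one is expected, partly because in this assay compound 1 gives 93% with a ring that also carries one sulfur, and partly since compound 4 keeps the same atoms as compound 3. Compound 4 is therefore estimated at 90%, within 70% to 115%. The expected step of a number 8 percentage points higher from compound 3 to compound 4 (within the scatter) is thus small and may not exceed the scatter.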

Compound 4, largest response reached (reported as maximum), in percent of the reference or control that the assay uses: 113%
Beside the measured number, compound 4's estimate is 23 percentage points below it; the range from low to high includes it.
By their numbers in this assay, from the lowest: compound 3; then compound 1; then compound 4; then compound 2.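

In this assay, the step of a number 31 percentage points higher from compound 3 to compound 4 (beyond the scatter) shows that the two thiazolyl rings are not interchangeable on this aromatic carbon, even though they hold the same atoms and the same counts of hydrogen-bond donors and acceptors. Each earlier step exchanged rings of differing atoms, so none of them could separate the way a ring is joined from what it contains, whereas here only the joining differs and the step is still large. The 1,3-thiazol-2-yl ring also falls within the span of the earlier rings, with a number 13 percentage points lower from compound 2 to compound 4 (beyond the scatter) and a number 20 percentage points higher from compound 1 to compound 4 (beyond the scatter), so the three sulfur-bearing rings of compound 1, compound 3 and compound 4 do not group together at the low end, although the furan-3-yl ring of compound 2 still gives the largest response.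

From the compounds shown here alone, it remains open whether a pyridinyl ring in this place, or an amine or a carboxylic acid carried on the 1,3-thiazol-2-yl ring, would hold or shift the response in this assay. Nothing available gives a reason for the size or direction of these steps.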